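Pepsin inhibitors: a benzyl group added to a ketone analogue

This account rests on a few compounds, and the source may have more. Where it says the series, first, only, none or still open, it means among the compounds named here.

The series comprises four peptide-like compounds tested in an assay on isolated protein for inhibition of Pepsin A (Sus scrofa); on this read-out lower numbers stand for stronger inhibition and higher numbers for weaker inhibition. Compound 1 `CC(C)CCNC(=O)C(C)NC(=O)C(Cc1ccccc1)C[C@H](O)[C@H](CC(C)C)NC(=O)C(NC(=O)CC(C)C)C(C)C` gives 2.5 nM in this assay, and compound 2 `CC(C)CC(=O)NC(C(=O)N[C@@H](CC(C)C)[C@@H](O)CC(C)C(=O)NC(C)C(=O)NC(=O)C(C)C)C(C)C` gives 3 nM, two numbers that sit within the scatter of one another. Compound 3 `CC(C)CCNC(=O)C(C)NC(=O)CCC(=O)[C@H](CC(C)C)NC(=O)C(NC(=O)CC(C)C)C(C)C` stands apart: in this assay compound 3 gives 2140 nM, the highest of the three numbers, and its gaps to compound 2 and to compound 1 both lie well beyond the scatter, so compound 3 is the weakest inhibitor measured so far.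

Compound 4 `CC(C)CCNC(=O)C(C)NC(=O)[C@@H](CC(=O)[C@H](CC(C)C)NC(=O)C(NC(=O)CC(C)C)C(C)C)Cc1ccccc1` has not yet been measured. It differs from compound 3 by benzyl in place of hydrogen on a saturated chain carbon bound to a carbonyl carbon and a saturated chain carbon. Compound 1 carries a benzyl group on its chain and gives 2.5 nM, whereas compound 3, without it, gives 2140 nM; the two also differ elsewhere, so the benzyl alone cannot be credited with the whole gap, but the comparison points toward a substantial drop in the number for compound 4. The step from compound 3 to compound 4 is therefore expected to be large and downward, of the size a 21-fold lower number from compound 3 to compound 4 (1.33 log units; beyond the scatter). On this basis compound 4 is estimated to give 100 nM in this assay, with a range from 20 nM to 600 nM.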

Compound 4, inhibition constant: 850 nM
Compound 4: middle estimate off by 8.5-fold (0.93 log units), on the low side, and the stated range ends below it.
By their numbers in this assay, from the lowest: compounds 1 and 2 (each within the scatter of the next); then compound 4; then compound 3.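

Placed on a saturated chain carbon bound to a carbonyl carbon and a saturated chain carbon, benzyl in place of hydrogen has only a modest effect in this assay (a 2.5-fold lower number from compound 3 to compound 4 (0.40 log units; beyond the scatter)), so on the ketone chain this position gives a real but small gain. Compound 1 also carries the benzyl group but has a hydroxyl where compound 4 has a carbonyl, and compound 4 at 850 nM stays well above compound 1 at 2.5 nM, which shows that adding benzyl to the ketone does not by itself reach the low number of compound 1. No measurement shown here accounts for the size of this step.

The compounds shown leave open how much the hydroxyl contributes on a chain without the benzyl group, since no compound here pairs that hydroxyl with a plain hydrogen at this carbon. They also leave open whether a different group on this carbon, such as a longer chain ending in phenyl, a cyclohexylmethyl group or an amine, would lower the number further than benzyl does.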